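Permeability of an Oxetan-3-yl Amine Analogue

The source may hold more compounds than are shown below. What is called first, only, known or untested is meant among the compounds shown, and "the series" means these compounds.

Measured compounds:
- compound 1, `NCCCCN(C[C@H]1Cc2ncccc2CN1)[C@H]1CCCc2cccnc21`: 17 nm/s
- compound 2, `NC(=O)NCCCCN(C[C@H]1Cc2ncccc2CN1)[C@H]1CCCc2cccnc21`: 7 nm/s
- compound 3, `c1cnc2c(c1)CN[C@@H](CN(CCCCNC1CCOCC1)[C@H]1CCCc3cccnc31)C2`: 2 nm/s

In an ADME assay for permeability, using PAMPA, with a stated time of 4 h, at pH 5.5 (on this read-out higher numbers stand for higher permeability and lower numbers for lower permeability), compound 1 gives 17 nm/s and stands highest of the three numbers shown; its nearest neighbour is compound 2 with 7 nm/s, and the furthest is compound 3 with 2 nm/s.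

The unmeasured compound 4, `c1cnc2c(c1)CN[C@@H](CN(CCCCNC1COC1)[C@H]1CCCc3cccnc31)C2`, differs from compound 1 in one place: oxetan-3-yl in place of hydrogen on an amine nitrogen. Among the compounds with values here, two measured steps bear on this change, since both also replace a hydrogen on the same amine nitrogen. The step of a 2.4-fold lower number from compound 1 to compound 2 (0.39 log units; beyond the scatter) lowered the number modestly, and the step of an 8.5-fold lower number from compound 1 to compound 3 (0.93 log units; beyond the scatter) lowered it further. Both point the same way, so a lowering beyond the scatter is expected for compound 4 in this assay, with the size likely between those two steps.

Compound 4 is therefore expected to show a step of a 4.3-fold lower number from compound 1 to compound 4 (0.63 log units; beyond the scatter), giving an estimated value of 4 nm/s, within a range from 1.5 nm/s to 10 nm/s.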

Compound 4, apparent permeability: 7 nm/s
Compound 4: the middle estimate sits 1.8-fold (0.24 log units) below what was measured; low and high end bracket the measured number.
By their numbers in this assay, from the lowest: compound 3; then compounds 2 and 4 (each within the scatter of the next); then compound 1.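

In this assay, oxetan-3-yl on this amine nitrogen gives a 2.4-fold lower number from compound 1 to compound 4 (0.39 log units; beyond the scatter), so all three groups measured here so far give a lower number than hydrogen. The size of that drop depends on the ring attached to the nitrogen: replacing oxan-4-yl with the four-membered ring of oxetan-3-yl gives a 3.5-fold higher number from compound 3 to compound 4 (0.54 log units; beyond the scatter). Replacing carbamoyl with oxetan-3-yl gives no change at the digits printed from compound 2 to compound 4 (within the scatter), so this assay does not separate these two groups, even though one is a ring and the other is not.

No supporting measurement is available to say why the numbers fall as they do. As far as these compounds go, it remains open whether a five-membered ring such as oxolan-3-yl would fall between the two rings, and where a simple methyl or acetyl group on the same nitrogen would stand.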